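Swapping an ether for a plain chain on the pyridine core

This account rests on a few compounds, and the source may have more. Where it says the series, first, only, none or still open, it means among the compounds named here.

Compound 1 `COCCCOc1nc(C(C)(C)C)ccc1CNC(=O)C(C)c1ccc(NS(C)(=O)=O)c(F)c1` and compound 2 `CC(C(=O)NCc1ccc(C(C)(C)C)nc1OCc1ccccc1)c1ccc(NS(C)(=O)=O)c(F)c1` share a core and differ only in the group on the ether oxygen. In an assay on cells for antagonist activity at transient receptor potential cation channel subfamily V member 1 (Homo sapiens), read by FLIPR and calcium flux, with a stated time of 6 min (on this read-out higher numbers stand for weaker inhibition and lower numbers for stronger inhibition), compound 1 gives 5.6 nM, and compound 2 gives 4.4 nM. For the measured compounds named here, the single measured step, a 1.3-fold lower number from compound 1 to compound 2 (0.10 log units; within the scatter), shows that exchanging 2-methoxyethyl for phenyl on the saturated chain carbon bound to the ring oxygen leaves the read-out essentially unchanged. Going by the values given here, compound 2 therefore stands within the scatter of compound 1, the only other number available.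

Compound 3 `CCCCCc1nc(C(C)(C)C)ccc1CNC(=O)C(C)c1ccc(NS(C)(=O)=O)c(F)c1` carries a further change: pentyl in place of benzyloxy on an aromatic carbon. Here the ether oxygen itself is lost together with the aromatic ring, so the one measured step does not speak directly to this change; it only shows that the tail beyond the oxygen can vary without effect. Among the compounds with values here, with no measured step covering the loss of the oxygen, the expected step of a 2.7-fold higher number from compound 2 to compound 3 (0.44 log units; beyond the scatter) is a modest weakening with wide uncertainty. Compound 3 is estimated at 12 nM, with a range from 4 nM to 40 nM.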

Compound 3, inhibition constant: 1.9 nM
Compound 3: middle estimate off by 6.3-fold (0.80 log units), on the high side; measured number outside the range, below it.
By their numbers in this assay, from the lowest: compound 3; then compounds 2 and 1 (each within the scatter of the next).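

In this assay, the place next to the ring nitrogen does not depend on an oxygen attached to the ring: pentyl, with no oxygen and no ring, gives a 2.3-fold lower number from compound 2 to compound 3 (0.36 log units; beyond the scatter) and, measured against the 3-methoxypropoxy group, a 2.9-fold lower number from compound 1 to compound 3 (0.47 log units; beyond the scatter) on the same core. Both steps are modest but beyond the scatter, whereas the two oxygen-linked groups stay within the scatter of each other, so among these three compounds the all-carbon chain is the only group separated from the others, and none of the three goes against this. Nothing available here explains the lower number seen with pentyl.

The compounds shown leave open whether the length of the chain matters, as pentyl is the only such chain here and neither a shorter propyl nor a longer heptyl chain is among them. They also leave open whether an amine attached to the ring at this same place would give numbers like those of compound 3 or like those of the two ethers.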